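This account rests on a few compounds, and the source may have more. Where it says the series, first, only, none or still open, it means among the compounds named here.

Notes on the series in a functional assay on MOLT-4 cells (Homo sapiens) for inhibition; on this read-out lower numbers stand for stronger inhibition and higher numbers for weaker inhibition.

Compound 1 `O=C1/C(=C/c2cccc(Cl)c2)Cc2ccccc21` gives 50900 nM in this assay. Compound 3 `O=C1/C(=C/c2cccc(Br)c2)Cc2ccccc21` carries the change bromo in place of chloro on an aromatic carbon relative to compound 1, and in this assay compound 3 gives 173000 nM. The step of a 3.4-fold higher number from compound 1 to compound 3 (0.53 log units; beyond the scatter) therefore goes toward a weaker read-out. Compound 2 `O=C1/C(=C/c2ccc(Cl)cc2)Cc2ccccc21` has the same atoms as compound 1 joined differently, and how the two cores differ is not broken down here. For compound 2 this assay reports only a limit, > 500000 nM, and that value is a limit of the assay rather than a number.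

Compound 4 `O=C1/C(=C/c2ccc(Br)cc2)Cc2ccccc21` is not yet measured. It differs from compound 2 by bromo in place of chloro on an aromatic carbon. Among the measured compounds shown here, this is the same kind of change as the one from compound 1 to compound 3, not the same change: in the pair of compound 1 and compound 3 the place is meta to a large group, whereas in the pair of compound 2 and compound 4 it is para to a large group. For the measured compounds named here, the only measured instance of this kind of change occurs once, in the step of a 3.4-fold higher number from compound 1 to compound 3 (0.53 log units; beyond the scatter), and it moved the number upward.

For compound 4 in this assay a step that the limit leaves unreadable from compound 2 to compound 4 is expected, resting on the modest upward step from compound 1 to compound 3 and on the fact that compound 2 already sits at the limit of > 500000 nM in this assay, at which 1 of the 3 values shown sits. Because the limit of > 500000 nM in this assay, at which 1 of the 3 values shown sits, applies to compound 2, compound 4 is expected most likely to return only a limit as well. The estimate for compound 4 in this assay is 1000000 nM, with a range from 300000 nM to 4000000 nM.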

Compound 4, half-maximal inhibitory concentration: > 500000 nM
Compound 4: no number, only a limit; the forecaster's own chance of this, stated with the estimate: 85%; the middle value is on the limit's open side.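

In this assay, among the compounds shown here, compound 2 and compound 4 both return only a limit, not a number, so no step between the two can be read: the limit of > 500000 nM in this assay, at which 2 of the 4 values shown sit.

The compounds shown leave open whether a 3.4-fold higher number from compound 1 to compound 3 (0.53 log units; beyond the scatter) has any counterpart in size or direction when bromo takes the place of chloro para to a large group.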